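Swapping methylsulfanyl for thiophene on the tetrazole ring

This account rests on a few compounds, and the source may have more. Where it says the series, first, only, none or still open, it means among the compounds named here.

Compound 1 `CCCCCCCCc1ccc(OCC(=O)Cn2nnc(C(=O)OC)n2)cc1`: in an assay on microsomes from brain for inhibition of Fatty-acid amide hydrolase 1 (Rattus norvegicus), read by fluorescence and HPLC, with a stated time of 60 min (on this read-out lower numbers stand for stronger inhibition and higher numbers for weaker inhibition), compound 1 gives 88 nM.
Compound 2 `CCCCCCCCc1ccc(OCC(=O)Cn2nnnc2SC)cc1`: in this assay compound 2 gives 22 nM.

For the measured compounds named here, compound 2 stands at the lowest of the two numbers measured so far; its nearest neighbour is compound 1, and the step of a 4.0-fold lower number from compound 1 to compound 2 (0.60 log units; beyond the scatter) lies beyond the scatter, so compound 2 is the stronger inhibitor of the two.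

Compound 3 `CCCCCCCCc1ccc(OCC(=O)Cn2nnnc2-c2cccs2)cc1` has not yet been measured. It differs from compound 2 in one place: thiophen-2-yl in place of methylsulfanyl on an aromatic carbon.

Going by the values given here, only one measured step exists, a 4.0-fold lower number from compound 1 to compound 2 (0.60 log units; beyond the scatter). That step exchanged the whole five-membered ring with four nitrogen atoms, its point of attachment and its substituent at once, so it bears only loosely on a swap of a single group on an aromatic carbon of that ring. Among the compounds with values here, no measured pair shows what a thiophen-2-yl does in place of methylsulfanyl. The expectation in this assay is therefore a step of modest size at most, with no firm direction.

For compound 3 the estimate is 30 nM, with a range from 8 nM to 120 nM. This estimate is expected to mean a step of a 1.4-fold higher number from compound 2 to compound 3 (0.13 log units; within the scatter).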

Compound 3, half-maximal inhibitory concentration: 55 nM
The estimate for compound 3 lay 1.8-fold (0.26 log units) below the measured number; the range from low to high includes it.
By their numbers in this assay, from the lowest: compound 2; then compounds 3 and 1 (each within the scatter of the next).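

In this assay, for the compounds shown here, the step of a 2.5-fold higher number from compound 2 to compound 3 (0.40 log units; beyond the scatter) gives the first direct reading of this aromatic carbon, since the earlier comparison changed the ring, its point of attachment and its substituent all at once. The result shows that the group on this carbon matters: the change is modest but beyond the scatter, and methylsulfanyl gives the stronger inhibition of the two. It also shows that a whole aromatic ring can sit here and still leave an inhibitor with a low nanomolar-range number, though the data hold nothing that explains the weakening.

As far as these compounds go, it remains open whether this loss belongs to thiophen-2-yl in particular or would follow any ring on this carbon, a question that phenyl or furan-2-yl could help to settle. Also open, from the compounds shown here alone, is how a longer sulfur-linked chain such as ethylsulfanyl, or a small amine, would compare with methylsulfanyl at the same place.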